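Fluoro for benzyl on the saturated ring carbon

The source may report more compounds than this note shows. Statements on the series, on what has been measured and on what is new or still open speak of the compounds shown alone.

Three compounds of the shared core have been run in a functional assay on the whole organism (Pleural cavity) for inhibition, with Rattus norvegicus as the target, at a dose of 25 mg/kg; a lower number here means less inhibition, a higher number more inhibition at the dose given (going by the name of the read-out). Compound 1 `CC1(C)C(=O)N(c2ccccc2Cl)c2ncccc21` gives 3% and compound 3 `CC1(C)C(=O)N(c2ccc(Br)cc2)c2ncccc21` gives 55% in this assay. Compound 2 `CC1(Cc2ccccc2)C(=O)N(c2ccccc2)c2ncccc21` gives 0% in this assay, the lowest of the three numbers: its gap to compound 1 lies within the scatter, while compound 3 stands well beyond the scatter above it. Among the compounds with values here, no pair among the measured compounds differs in a single place, so no measured step is available.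

Compound 4 `CC1(F)C(=O)N(c2ccccc2)c2ncccc21` is not yet measured. It differs from compound 2 by fluoro in place of benzyl on a saturated ring carbon. The phenyl on the ring nitrogen is kept as in compound 2, and the data hold no measured change at the saturated ring carbon, so the size and direction of the step are open. The expectation is a small step from compound 2, a number 10 percentage points higher from compound 2 to compound 4 (within the scatter), not clearly beyond the scatter, because compound 2 gives 0% and compound 1, also low, gives 3%. Compound 4 is estimated at 10% in this assay, with a range from 0% to 35%.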

Compound 4, a percentage reported as inhibition, in the whole organism at one dose (the size of the read-out at that dose, not a potency): 35%
Compound 4: the middle estimate sits 25 percentage points below what was measured; the range from low to high includes it.
By their numbers in this assay, from the lowest: compounds 2 and 1 (each within the scatter of the next); then compound 4; then compound 3.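

In this assay, the saturated ring carbon now has its first measured change: with the phenyl on the ring nitrogen kept, fluoro in place of benzyl gives a number 35 percentage points higher from compound 2 to compound 4 (beyond the scatter). The number at this position therefore moves with the group it carries, a point that compounds 1, 2 and 3 could not show, as none of them forms a single-place pair with another. Nothing at hand accounts for the step.

On these data alone, compound 4 removes benzyl and brings in fluoro in one change, so the shares of the two stay open. A hydroxyl or an amine on the same saturated ring carbon, with the phenyl on the ring nitrogen kept, would show whether the number follows fluoro itself or the absence of benzyl.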